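Removing a Methyl Group from the Strongest of Three Inhibitors

The compounds below may be only part of what the source reports. "The series", "measured", "known", "first", "only" and "open" are said of these compounds alone.

Of the compounds shown here, three have so far been tested in a functional assay on HeLa cells (Homo sapiens) for inhibition (on this read-out lower numbers stand for stronger inhibition and higher numbers for weaker inhibition), and all three carry a 2-formylethenyl group. Compound 1 (`Cc1cn(/C=C/C=O)c(=O)[nH]c1=O`) gives 1 uM as its reading, the lowest number of the three and so the strongest inhibition. Compound 2 (`Nc1ccn(/C=C/C=O)c(=O)n1`) gives 15 uM and compound 3 (`Nc1nc(O)c2ncn(/C=C/C=O)c2n1`) gives 24 uM on the same read-out. Both numbers lie beyond the usual scatter from that of compound 1, while the two sit within the scatter of each other. No two of these compounds differ in one place only, so no measured step isolates a single change.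

Compound 4 (`O=C/C=C/n1ccc(=O)[nH]c1=O`) is still to be measured in this assay and differs from compound 1 by one change: hydrogen in place of methyl on an aromatic carbon. For the measured compounds named here, the data hold no measured example of this change, so the expectation rests on the change itself and on compound 1 at 1 uM having the lowest number so far. The estimated step of a 3.0-fold higher number from compound 1 to compound 4 (0.48 log units; beyond the scatter) is a modest rise in the number, meaning somewhat weaker inhibition. For compound 4 the expected value is 3 uM within an estimated range of 1 uM to 10 uM on this read-out.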

Compound 4, concentration for 50% inhibition: 4 uM
Compound 4: middle estimate off by 1.3-fold (0.12 log units), on the low side, and the stated range covers the measured number.
By their numbers in this assay, from the lowest: compound 1; then compound 4; then compounds 2 and 3 (each within the scatter of the next).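

In this assay, for the compounds shown here, replacing the methyl with hydrogen gives a 4.0-fold higher number from compound 1 to compound 4 (0.60 log units; beyond the scatter) and is the first step in this set that isolates a single change. It shows that the methyl on this aromatic carbon, meta to the 2-formylethenyl group, accounts for a modest loss of inhibition beyond the scatter when it leaves, while compound 4 still reads 4 uM and so remains an inhibitor on this read-out without it. Nothing measured on these compounds explains why this single carbon makes the difference.

As far as these compounds go, only methyl and hydrogen have been seen at this position, so it remains open whether an ethyl group, a chlorine atom or a hydroxymethyl group would give a reading nearer that of compound 1, nearer that of compound 4, or outside both. It is also open whether a change at a single place would matter to the same extent on the cores of compound 2 and compound 3, as neither has a partner among the compounds shown that differs from it in one place only.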